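Bromo-to-methyl swap on the benzyl ring: series notes

The source may report more compounds than this note shows. Statements on the series, on what has been measured and on what is new or still open speak of the compounds shown alone.

Compound 1 `COc1cc(N(Cc2ccc(Br)cc2)C(=O)CSC(=S)N2CCN(C(=O)OC(C)(C)C)CC2)cc(OC)c1OC` and compound 2 `COc1cc(N(Cc2ccc(C)cc2)C(=O)CSC(=S)N2CCN(C(=O)OC(C)(C)C)CC2)cc(OC)c1OC` share one core; their difference is methyl in place of bromo on an aromatic carbon. In a functional assay on MGC-803 cells (Homo sapiens) for inhibition, read by CCK-8 assay, with a stated time of 48 h (on this read-out higher numbers stand for weaker inhibition and lower numbers for stronger inhibition), compound 1 gives 12400 nM, and compound 2 gives 16700 nM, so the step is a 1.3-fold higher number from compound 1 to compound 2 (0.13 log units; within the scatter). Compound 3 `COc1ccc(CN(C(=O)CSC(=S)N2CCN(C(=O)OC(C)(C)C)CC2)c2cc(OC)c(OC)c(OC)c2)cc1Br` carries a different core, and its difference from compound 1 is 3-bromo-4-methoxyphenyl in place of 4-bromophenyl on a saturated chain carbon bound to an amide-type nitrogen. In this assay compound 3 gives 3710 nM, which stands as a 3.3-fold lower number from compound 1 to compound 3 (0.52 log units; beyond the scatter) and as a 4.5-fold lower number from compound 2 to compound 3 (0.65 log units; beyond the scatter). Compound 4 `COc1ccc(CN(C(=O)CSC(=S)N2CCN(C(=O)OC(C)(C)C)CC2)c2cc(OC)c(OC)c(OC)c2)cc1C` has not been measured; it differs from compound 3 by methyl in place of bromo on an aromatic carbon. This is the same kind of change as that from compound 1 to compound 2, but the place is not the same: in compound 1 the group sits para to a large group, whereas in compound 3 it sits ortho to a methoxy group and meta to a large group. Because the earlier step of a 1.3-fold higher number from compound 1 to compound 2 (0.13 log units; within the scatter) stayed within the scatter, the step expected from compound 3 to compound 4 in this assay is a 1.3-fold higher number from compound 3 to compound 4 (0.11 log units; within the scatter). The place differs, so the range is kept wide. For compound 4 the estimate is 4800 nM. The expected lower end for compound 4 is 2000 nM and the expected upper end for compound 4 is 12000 nM.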

Compound 4, half-maximal inhibitory concentration: > 20000 nM
Compound 4 gave a limit, no number; the forecaster's own chance of this, stated with the estimate: 3%; at least 4.1-fold (0.61 log units) between middle value and limit.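

Compound 4 gives > 20000 nM in this assay, which is a limit of the assay and not a number. On this second core, methyl in place of bromo gives an at least 5.3-fold higher number from compound 3 to compound 4 (0.73 log units; beyond the scatter), so the small step seen on the first core does not carry over: the same change on two cores in this assay, a 1.3-fold higher number (0.13 log units; within the scatter) from compound 1 to compound 2 and an at least 5.3-fold higher number (0.73 log units; beyond the scatter) from compound 3 to compound 4, at least 4.0-fold (0.60 log units) apart, beyond the scatter of two such steps With an at least 1.1-fold higher number from compound 2 to compound 4 (0.07 log units; that floor lies within the scatter) and an at least 1.6-fold higher number from compound 1 to compound 4 (0.20 log units; that floor lies within the scatter), both floors within the scatter, no separation is shown on those comparisons, and two cores show neither the full size of the gap nor why the change behaves differently on each, as the new step rests on a limit: the limit of > 20000 nM in this assay, at which 1 of the 4 values shown sits.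

Still open, on these data alone, is what chloro or a nitrile at the same place would give on the 4-methoxybenzyl group, and so whether the result in this assay is specific to bromo. Also open, as far as these compounds go, is whether the difference between cores would hold with a free amine on the piperazine in place of the tert-butyl carbamate.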